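Swapping the aryl group on a pyrazole sulfonate pain reliever

The source may report more compounds than this note shows. Statements on the series, on what has been measured and on what is new or still open speak of the compounds shown alone.

Measured compounds:
- Compound 1, `Cc1ccc(-c2cc(C)n(S(=O)(=O)Oc3ccccc3)n2)cc1`: 50.7%
- Compound 2, `Cc1cc(-c2ccc(C(F)(F)F)cc2)nn1S(=O)(=O)Oc1ccccc1`: 25.8%
- Compound 3, `CCc1ccc(-c2cc(C)n(S(=O)(=O)Oc3ccccc3)n2)cc1`: 48.1%

The three compounds share one core and differ only in the aryl group attached to it. In a functional assay on the whole organism for inhibition, with Mus musculus as the target, in the writhing test, with stated times of 3 days and 20 min, at a dose of 30 mg/kg by the oral route (a higher number here means more inhibition at the dose given (going by the name of the read-out), a lower number less inhibition), compound 3 stands second highest of the three; its nearest neighbour is compound 1, a number 2.6 percentage points lower from compound 1 to compound 3 (within the scatter), and its furthest is compound 2, a number 22.3 percentage points higher from compound 2 to compound 3 (beyond the scatter).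

Compound 4, `Cc1cc(-c2cccc(Cl)c2)nn1S(=O)(=O)Oc1ccccc1`, has not yet been tested. It differs from compound 3 in one place: 3-chlorophenyl in place of 4-ethylphenyl on an aromatic carbon.

Within the data shown here, two measured steps bear on this change, both touching the same aryl group: a number 24.9 percentage points lower from compound 1 to compound 2 (beyond the scatter), and a number 22.3 percentage points higher from compound 2 to compound 3 (beyond the scatter). Both were modest and both show that replacing an alkyl group on that ring with trifluoromethyl lowers inhibition in this assay. A chlorine at a different position on the ring is a change of another kind, so the numbers give only a rough guide; a modest drop is expected but far from certain. The estimated step is a number 10.1 percentage points lower from compound 3 to compound 4 (beyond the scatter). For compound 4 the estimate in this assay is 38%, with a range from 22% to 55%.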

Compound 4, a percentage reported as inhibition, in the whole organism at one dose (the size of the read-out at that dose, not a potency): 18.9%
Compound 4: the middle estimate sits 19.1 percentage points above what was measured; measured number below the stated range.
By their numbers in this assay, from the lowest: compounds 4 and 2 (each within the scatter of the next); then compounds 3 and 1 (each within the scatter of the next).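

In this assay, the aryl group on the shared core proves sensitive to more than trifluoromethyl: changing to 3-chlorophenyl gives a number 29.2 percentage points lower from compound 3 to compound 4 (beyond the scatter) and a number 31.8 percentage points lower from compound 1 to compound 4 (beyond the scatter). Compound 4 lands within the scatter of compound 2, so two different aryl groups now share the low level, while the alkyl-bearing compounds 1 and 3 share the higher one. No measurement here explains this drop.

This change swaps the ethyl for a chlorine and also moves the substituent to another ring place, so the compounds shown cannot say which of the two matters. A 4-chlorophenyl would separate them, and a 4-methoxyphenyl or a longer alkyl chain on the ring remains an open comparison.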